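The source may hold more compounds than are shown below. What is called first, only, known or untested is meant among the compounds shown, and "the series" means these compounds.

Series notes. Compound 1 `O=C(O)Cc1sc(CS(=O)(=O)c2ccc(Cl)cc2)nc1-c1ccc(Cl)cc1`, compound 2 `O=C(O)Cc1sc(C2COc3ccccc3O2)nc1-c1ccc(Cl)cc1` and compound 3 `N#Cc1cc(-c2nc(C(c3ccc(F)cc3)c3ccc(F)cc3)sc2CC(=O)O)ccc1F` share a core carrying a carboxymethyl group and have each been run in an in vitro functional assay on HEK285-7 cells for antagonist activity at prostaglandin D2 receptor 2 (Homo sapiens), read by BRET and beta-arrestin recruitment; on this read-out higher numbers stand for weaker inhibition and lower numbers for stronger inhibition. Compound 1 gives 730 nM, compound 2 gives 2000 nM and compound 3 gives 520 nM. Compound 3 thus carries the lowest of the three numbers, although its gap to compound 1 lies within the scatter of repeated measurements; only its gap to compound 2 lies beyond it.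

Compound 4 `Nc1cc(-c2nc(C(c3ccc(F)cc3)c3ccc(F)cc3)sc2CC(=O)O)cc(F)n1` has not yet been measured in this assay. It differs from compound 3 in one place: 2-amino-6-fluoropyridin-4-yl in place of 3-cyano-4-fluorophenyl on an aromatic carbon. Among the measured compounds shown here, no measured pair shows a change of this kind, so there is nothing to fix a direction for it. The expectation for the step from compound 3 to compound 4 is therefore no step beyond the scatter, in either direction, a 1.2-fold higher number from compound 3 to compound 4 (0.06 log units; within the scatter). On that basis compound 4 is estimated at 600 nM in this assay, with a range from 200 nM to 2000 nM allowing for the unknown effect of the new aryl group.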

Compound 4, half-maximal inhibitory concentration: 1400 nM
Estimate against measurement, compound 4: 2.3-fold (0.37 log units) below; measured number inside the range.
By their numbers in this assay, from the lowest: compounds 3, 1, 4 and 2 (each within the scatter of the next, the first and the last beyond it).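

In this assay the aryl group on the aromatic carbon next to the ring nitrogen proves able to move the number: 2-amino-6-fluoropyridin-4-yl in place of 3-cyano-4-fluorophenyl gives a 2.7-fold higher number from compound 3 to compound 4 (0.43 log units; beyond the scatter) and so provides the only single-place comparison among the compounds shown. The diaryl-substituted side of the core stays constant across this pair, which ties the step to the exchanged aryl group alone. No available evidence accounts for the step.

Within that aryl group, the nitrile, the amine and the ring nitrogen all change together, so their separate contributions remain open. Also open, as far as these compounds go, is whether an unsubstituted phenyl ring or a methoxypyridine at this place would give a number nearer that of compound 3 or that of compound 4.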